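This account rests on a few compounds, and the source may have more. Where it says the series, first, only, none or still open, it means among the compounds named here.

Compound 3 `c1ccc(-c2nnnn2Cc2cccnc2)cc1` gives 25100 nM in an in vitro functional assay on 1321-N1 cells for antagonist activity at P2X purinoceptor 7 (Homo sapiens), read by FLIPR and calcium flux (a lower number here means a stronger inhibitor, a higher number a weaker inhibitor), the highest of the three numbers: compound 2 `Cc1nc(C)c(Cn2nnnc2-c2cccc(Cl)c2Cl)s1` gives 50.1 nM and compound 1 `Cc1ncccc1Cn1nnnc1-c1cccc(Cl)c1Cl` gives 31.6 nM, both far lower and beyond the scatter. Compound 4 `Clc1ccccc1-c1nnnn1Cc1cccnc1` differs from compound 3 by chloro in place of hydrogen on an aromatic carbon. For the measured compounds named here, no measured step alters this place: the only single-point step, a 1.6-fold higher number from compound 1 to compound 2 (0.20 log units; within the scatter), changes the group on the chain carbon, not the phenyl ring. Compound 1 and compound 2 carry chloro substitution on that ring where compound 3 has none, but they also differ from compound 3 at the chain carbon, so the gap cannot be assigned to chloro alone. A substantial fall in this assay is nevertheless expected for compound 4, a 13-fold lower number from compound 3 to compound 4 (1.10 log units; beyond the scatter). Compound 4 is estimated at 2000 nM, range 500 nM to 8000 nM.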

Compound 4, half-maximal inhibitory concentration: 15800 nM
The estimate for compound 4 lay 7.9-fold (0.90 log units) below the measured number; measured number outside the range, above it.
By their numbers in this assay, from the lowest: compounds 1 and 2 (each within the scatter of the next); then compounds 4 and 3 (each within the scatter of the next).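

In this assay, chloro in place of hydrogen on an aromatic carbon, ortho to a large group, gives a 1.6-fold lower number from compound 3 to compound 4 (0.20 log units; within the scatter) and so does not separate the pair. At this place, on a ring otherwise unsubstituted, chloro alone is not distinguished from hydrogen. Nothing at hand speaks to the reason for this result.

Open, on these data alone, is whether methoxy or trifluoromethyl at this place would read differently from chloro. Also open, as far as these compounds go, is whether chloro gives the same small step with 2-methylpyridin-3-yl on the chain carbon.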